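A few compounds are considered here, and "the series" means these few. Any claim that something is new, unique, unknown or untested is made for them only; others in the source may bear on it.

Compound 1 `Nc1nc(N)c2c(-c3cc4ccccc4o3)cn([C@@H]3O[C@H](CO)[C@@H](O)[C@H]3O)c2n1`: 78500 nM in an ADME assay on MRC5 cells (Homo sapiens), read by MTT assay, with a stated time of 72 h; a lower number here means a stronger inhibitor, a higher number a weaker inhibitor.
Compound 2 `C#Cc1cn([C@@H]2O[C@H](CO)[C@@H](O)[C@H]2O)c2ncnc(OC)c12`: > 100000 nM, a limit of the assay and not a number.
Compound 3 `Nc1nc(N)c2c(-c3ccoc3)cn([C@@H]3O[C@H](CO)[C@@H](O)[C@H]3O)c2n1`: > 100000 nM, likewise only a limit.

In this assay compound 2 thus stands at the edge of what the assay can report, the place where most values shown sit (the limit of > 100000 nM in this assay, at which 2 of the 3 values shown sit). Compound 4 `COc1ncnc2c1c(-c1ccco1)cn2[C@@H]1O[C@H](CO)[C@@H](O)[C@H]1O` differs from compound 2 by furan-2-yl in place of ethynyl on an aromatic carbon. Among the measured compounds shown here, the single measured step, an at least 1.2-fold higher number from compound 1 to compound 3 (0.10 log units; that floor lies within the scatter), exchanges one furan-bearing group for another on a different core and does not include the loss of ethynyl, so it offers no direct guide. The expected step is a step that the limit leaves unreadable from compound 2 to compound 4, nothing beyond the scatter in either direction. Compound 4 is therefore estimated at 120000 nM, within a range from 40000 nM to 400000 nM, and may well come back only as a limit again.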

Compound 4, half-maximal inhibitory concentration: 1700 nM
Compound 4: the middle estimate sits 71-fold (1.85 log units) above what was measured; measured number below the stated range.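

On this aromatic carbon, furan-2-yl in place of ethynyl gives an at least 58-fold lower number from compound 2 to compound 4 (1.76 log units; beyond the scatter) in this assay, the first step shown that lies beyond the scatter. The group carried at this position can therefore change the number strongly, at least for this pair. From the compounds shown here alone, the full size of the step stays unknown because compound 2 gives only a limit: the limit of > 100000 nM in this assay, at which 2 of the 4 values shown sit.

Going by these compounds, whether a phenyl group or an amine on this carbon would also lower the number stays open. On these data alone, it is equally open whether furan-2-yl would do the same on the core of compound 1.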